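The source may hold more compounds than are shown below. What is called first, only, known or untested is meant among the compounds shown, and "the series" means these compounds.

In a functional assay on OVCAR-5 cells (Homo sapiens) for inhibition, read by CCK-8 assay, with a stated time of 72 h, tested at 1 uM (a higher number here means more inhibition of growth at the concentration tested, a lower number less inhibition of growth), three compounds have been measured so far. Compound 1 (`CN(C)C(=O)c1cc2cnc(Nc3ccc(NC(=O)C4(C(=O)Nc5ccc(F)cc5)CC4)cc3)nc2n1C1CCCC1`) gives 65.4%, compound 2 (`CN(C)C(=O)c1cc2cnc(Nc3ccc(N)cn3)nc2n1C1CCCC1`) gives 12.3%, and compound 3 (`CN(C)C(=O)c1cc2cnc(Nc3ccc(NC(=O)C4(C(=O)Nc5ccc(Cl)cc5)CC4)cc3)nc2n1C1CCCC1`) gives 8.1%. Compound 3 therefore lies within the scatter of compound 2 and far under compound 1.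

The next compound, compound 4 (`CN(C)C(=O)c1cc2cnc(Nc3ccc(NC(=O)C4(C(=O)Nc5cccc(O)c5)CC4)cc3)nc2n1C1CCCC1`), carries 3-hydroxyphenyl in place of 4-chlorophenyl on an amide-type nitrogen. Counted out, the change is 3-hydroxyphenyl in place of 4-chlorophenyl on an amide-type nitrogen.

Going by the values given here, only one measured step touches this aromatic ring: chloro in place of fluoro on an aromatic carbon, which is a number 57.3 percentage points lower from compound 1 to compound 3 (beyond the scatter). That large step shows that a single swap on this ring can move the result a long way. Compound 2 differs from compound 3 in more than one place, so it offers no clean comparison. Among the compounds with values here, no measured compound carries a hydroxyl group, so the data give the direction only tentatively. Compound 4 gives up the chloro found in compound 3, and with compound 1 at 65.4% as the one clear sign of room above, a moderate rise seems more likely than none.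

The expected step is a number 21.9 percentage points higher from compound 3 to compound 4 (beyond the scatter), with wide uncertainty. For compound 4 the estimate is 30%, with an expected range from 5% to 65%.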

Compound 4, percent growth inhibition at one concentration: 58.5%
Compound 4: the middle estimate sits 28.5 percentage points below what was measured; the measured number falls inside the stated range.
By their numbers in this assay, from the lowest: compounds 3 and 2 (each within the scatter of the next); then compounds 4 and 1 (each within the scatter of the next).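

In this assay, putting 3-hydroxyphenyl on the amide-type nitrogen in place of 4-chlorophenyl gives a large change, a step of a number 50.4 percentage points higher from compound 3 to compound 4 (beyond the scatter), so a low reading is not shared by every substituted phenyl ring at this place. Replacing 4-fluorophenyl with the same group gives a step of a number 6.9 percentage points lower from compound 1 to compound 4 (within the scatter), which means two differently substituted rings read alike here, and among the three rings shown on this nitrogen only 4-chlorophenyl stands apart. Nothing available explains why these rings give such different readings.

The compounds shown leave open whether the hydroxyl itself or its place on the ring matters more, since the group and its place change together in both swaps. A methoxy group or an amine on this ring, or a plain unsubstituted phenyl ring, would show how widely this place accepts change and whether the low reading with 4-chlorophenyl is an isolated case.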